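The compounds below may be only part of what the source reports. "The series", "measured", "known", "first", "only" and "open" are said of these compounds alone.

Measured compounds in a functional assay on P388 cells (Mus musculus) for cytotoxicity, read by MTT assay, with a stated time of 72 h; on this read-out higher numbers stand for weaker inhibition and lower numbers for stronger inhibition:
- compound 1, `OCC#CCSc1cnc2ccccc2c1Cl`, gives 2.4 ug/mL
- compound 2, `OCC#CCSc1cnc2ccccc2c1SCC#CCBr`, gives 43.2 ug/mL
- compound 3, `OCC#CCSc1cnc2ccccc2c1SCC#CCO`, gives 5.7 ug/mL

Compound 3 stands second highest of the three numbers; its nearest neighbour is compound 1, with the step of a 2.4-fold higher number from compound 1 to compound 3 (0.38 log units; beyond the scatter), and its furthest is compound 2, with the step of a 7.6-fold lower number from compound 2 to compound 3 (0.88 log units; beyond the scatter). Compound 4, `CSc1c(SCC#CCO)cnc2ccccc12`, differs from compound 3 by hydrogen in place of 3-hydroxyprop-1-yn-1-yl on a saturated chain carbon bound to a sulfur.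

Among the compounds with values here, no measured step removes this chain outright; the closest guide is the step of a 2.4-fold higher number from compound 1 to compound 3 (0.38 log units; beyond the scatter), in which the whole hydroxybutynylthio group entered in place of chlorine and the number rose modestly, and the step of an 18-fold higher number from compound 1 to compound 2 (1.26 log units; beyond the scatter), in which the bromo analogue entered and the number rose sharply. Within the pair of measured thioethers, trading bromo for hydroxy at the chain end gave a 7.6-fold lower number from compound 2 to compound 3 (0.88 log units; beyond the scatter). Taken together these show that the sulfur-linked chain at this position moves the number by a modest to large amount depending on its terminus, so shortening it to methyl is expected to give a modest step in this assay, most likely a somewhat lower number, back towards compound 1.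

Compound 4 is therefore estimated at 4 ug/mL, with a range from 1.5 ug/mL to 12 ug/mL, corresponding to an expected step of a 1.4-fold lower number from compound 3 to compound 4 (0.15 log units; within the scatter).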

Compound 4, concentration for 50% inhibition: 32.3 ug/mL
Compound 4: the middle estimate sits 8.1-fold (0.91 log units) below what was measured, outside the stated range (above it).
By their numbers in this assay, from the lowest: compound 1; then compound 3; then compounds 4 and 2 (each within the scatter of the next).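

In this assay, cutting 4-hydroxybut-2-yn-1-yl to methyl on the sulfur gives a 5.7-fold higher number from compound 3 to compound 4 (0.75 log units; beyond the scatter) and so does not lead back towards compound 1; with methylsulfanyl in place of chloro, the core carries a 13-fold higher number from compound 1 to compound 4 (1.13 log units; beyond the scatter) as its step, so a short sulfur substituent is no closer to the chloro compound than the hydroxy-ended chain of compound 3. The bromo-ended chain and methyl cannot be separated, with a 1.3-fold lower number from compound 2 to compound 4 (0.13 log units; within the scatter) as the step, so among these three thioethers the number does not follow chain length, and compound 3 alone stands apart from the other two. No measurement at hand accounts for these steps.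

The compounds shown leave open whether the hydroxy end or the triple bond carries the difference between compound 3 and compound 4, which a saturated 4-hydroxybutyl chain or a shorter 2-hydroxyethyl chain on the same sulfur would address. From the compounds shown here alone, how an amine or a carboxylic acid at the chain end would sit against the hydroxy and bromo ends also remains open.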